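Oxime side group replaced on the shared core

The source may report more compounds than this note shows. Statements on the series, on what has been measured and on what is new or still open speak of the compounds shown alone.

Compounds 1, 2 and 3 share one core and differ only in the group carried on one aromatic carbon. Compound 1 `C/C(=N\OCCSc1nnc(C)s1)c1ccc(Sc2cc(F)cc(C3CCOCC3)c2)cc1` gives 230 nM in a functional assay (blood) for inhibition, with Homo sapiens as the target; a lower number here means a stronger inhibitor, a higher number a weaker inhibitor. Going by the values given here, compound 2 `C/C(=N\OCCSc1nnnn1C)c1ccc(Sc2cc(F)cc(C3CCOCC3)c2)cc1` gives 120 nM in this assay, and the step of a 1.9-fold lower number from compound 1 to compound 2 (0.28 log units; within the scatter) is the only single change measured so far: 1-methyl-1H-tetrazol-5-yl in place of 5-methyl-1,3,4-thiadiazol-2-yl on a sulfur. Compound 3 `CS/C(=N\O)c1ccc(Sc2cc(F)cc(C3CCOCC3)c2)cc1` gives 190 nM in this assay; this number lies within the scatter of both compound 1 and compound 2, so the three compounds are not separated by these measurements.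

Compound 4 `CC(=O)O/N=C(\C)c1ccc(Sc2cc(F)cc(C3CCOCC3)c2)cc1` has not yet been measured. From compound 3 to compound 4 the change is a group of 7 heavy atoms (4 carbon, 1 nitrogen, 2 oxygen; no ring) in place of a group of 5 heavy atoms (2 carbon, 1 nitrogen, 1 oxygen, 1 sulfur; no ring), on an aromatic carbon. Among the compounds with values here, the one measured step swaps a ring on a sulfur and stayed within the scatter; it does not touch the part altered here, so no measured step bears directly on this change, and the series so far shows no change beyond the scatter for any variation at this position. The expected step of a 1.1-fold higher number from compound 3 to compound 4 (0.02 log units; within the scatter) is therefore none beyond the scatter. Compound 4 is expected to give 200 nM in this assay, with a range from 70 nM to 550 nM.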

Compound 4, half-maximal inhibitory concentration: 50 nM
Compound 4: middle estimate off by 4.0-fold (0.60 log units), on the high side; the measured number lies below the stated range.
By their numbers in this assay, from the lowest: compound 4; then compounds 2, 3 and 1 (each within the scatter of the next).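

Going by these compounds alone, this position gives the first change that lies beyond the scatter in this assay: a 3.8-fold lower number from compound 3 to compound 4 (0.58 log units; beyond the scatter), with acetyl on the oxime oxygen. Against the two longer side chains on that oxygen, acetyl gives a 2.4-fold lower number from compound 2 to compound 4 (0.38 log units; beyond the scatter) and a 4.6-fold lower number from compound 1 to compound 4 (0.66 log units; beyond the scatter), so compound 4 holds the lowest number of the four, whereas the ring swap within those side chains stayed within the scatter. Nothing available accounts for these steps.

The compounds shown leave open whether the carbonyl of the acetyl group is needed, since a plain methyl, a propanoyl chain or a benzoyl group on the same oxygen does not appear among them. Also open, as far as these compounds go, is whether acetyl gives a similar step on any core other than the shared one.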